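This account rests on a few compounds, and the source may have more. Where it says the series, first, only, none or still open, it means among the compounds named here.

The measured compounds:
compound 1 `C/C(=N\O)c1ccc(NC(=O)Cn2nc(-c3ccc(Cl)cc3)nc2N)cc1` with 12%
compound 2 `c1ccc(-c2nc3sc(-c4ccccc4)cn3n2)cc1` with 15%

Two compounds have been run in a functional assay on SNB-75 cells (Homo sapiens) for inhibition, read by sulforhodamine B assay, with a stated time of 48 h, tested at 10 uM; on this read-out lower numbers stand for less inhibition of growth and higher numbers for more inhibition of growth at the one concentration tested. Compound 1 stands alongside compound 2: in this assay compound 1 gives 12%, and compound 2 gives 15%, numbers that lie within the usual scatter of each other, so nothing separates them. Among the measured compounds shown here, no step between the measured pair is given, and compound 2 shares no single-point change with compound 1.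

Compound 3 `CC(=O)c1ccc(NC(=O)Cn2nc(-c3ccc(Cl)cc3)nc2N)cc1` has not yet been measured. It differs from compound 1 in one place: a group of 3 heavy atoms (2 carbon, 1 oxygen; no ring) in place of a group of 4 heavy atoms (2 carbon, 1 nitrogen, 1 oxygen; no ring), on an aromatic carbon An acetyl enters where the group with one hydrogen-bond donor left. With only these two numbers at hand, the expectation is that the step of a number 1 percentage points higher from compound 1 to compound 3 (within the scatter) stays small, in no clear direction and not beyond the scatter. Compound 3 is therefore expected to give about 13%, within a range from 0% to 30%.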

Compound 3, percent growth inhibition at one concentration: 6.47%
Beside the measured number, compound 3's estimate is 6.5 percentage points above it, within the range that was stated.
By their numbers in this assay, from the lowest: compounds 3, 1 and 2 (each within the scatter of the next).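

In this assay, among the compounds shown here, the first single-point comparison at this position, on an aromatic carbon para to a large group, gives a number 5.5 percentage points lower from compound 1 to compound 3 (within the scatter). Acetyl, with 0 hydrogen-bond donors, thus takes the place of a group with 1 hydrogen-bond donor without separating the two compounds, so this one change shows no measurable effect on the read-out at this position. Nothing measured here explains the numbers of these two compounds or ties them to any property of either group.

The compounds shown leave open whether any other group at this position, such as an amine, a carboxylic acid or a longer chain, would move the number in this assay beyond the scatter. They also leave open whether a change elsewhere on the core of compound 1 would do so.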